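The compounds below may be only part of what the source reports. "The series", "measured", "known", "first", "only" and "open" are said of these compounds alone.

Of the compounds shown here, two sharing one core have been measured in a functional assay on a cell-free system (plasma) for inhibition of thromboxane A2 receptor (Homo sapiens); a higher number here means a weaker inhibitor, a lower number a stronger inhibitor. Compound 1, `CCCCCCS(=O)(=O)CC1C2CCC(O2)C1C/C=C\CCCC(=O)O`, gives 25000 nM. Compound 2, `O=C(O)CCC/C=C\CC1C2CCC(O2)C1CSCCc1ccccc1`, gives 5500 nM, the lowest of the two numbers; the gap between compound 1 and compound 2 is beyond the usual scatter, so compound 2 counts as the stronger inhibitor of the pair. The next compound, compound 3, `CCC/C=C/CSCC1C2CCC(O2)C1C/C=C\CCCC(=O)O`, has not yet been measured. It differs from compound 2 in one place: pent-1-en-1-yl in place of benzyl on a saturated chain carbon bound to a sulfur. Within the data shown here, no pair of measured compounds shows this exact change, so its effect can only be guessed. Both the benzyl that leaves and the pent-1-en-1-yl that enters carry no hydrogen-bond donors or acceptors and no charge, and the chain stays on the sulfur, so the step from compound 2 to compound 3 is expected to be small, a 1.3-fold higher number from compound 2 to compound 3 (0.10 log units; within the scatter), perhaps none beyond the scatter. Compound 3 is therefore expected to give about 7000 nM in this assay, within a range from 2500 nM to 20000 nM.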

Compound 3, half-maximal inhibitory concentration: 1300 nM
Beside the measured number, compound 3's estimate is 5.4-fold (0.73 log units) above it; the measured number lies below the stated range.
By their numbers in this assay, from the lowest: compound 3; then compound 2; then compound 1.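

In this assay, the step gives a 4.2-fold lower number from compound 2 to compound 3 (0.63 log units; beyond the scatter), so inhibition responds to the group at this position, on a saturated chain carbon bound to a sulfur, even when neither group carries hydrogen-bond donors, acceptors or a charge. In this pair, the six-membered aromatic ring of benzyl is not needed for inhibition, since pent-1-en-1-yl, with no ring and one double bond, gives the lower number. Nothing available here explains the direction or size of this step.

This single change alters chain size, the ring and the double bond together, so the compounds shown cannot say which of these accounts for the step. A saturated pentyl group at the same place would show whether the double bond matters, and a cyclohexyl group would test a ring that is not aromatic.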